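From Cyclopentylamino to Methylsulfanyl on a Shared Core

The source may hold more compounds than are shown below. What is called first, only, known or untested is meant among the compounds shown, and "the series" means these compounds.

Measured in an ADME assay on Akata cells (Homo sapiens) for cytotoxicity, with a stated time of 7 days (a lower number here means that less compound is tolerated, a higher number that more compound is tolerated), with each entry a limit and not a number:
- compound 1 `C=CCOc1nc(N)nc2c1ncn2/C=C1/CC1(CO)CO` gives > 20000 nM as a limit
- compound 2 `Nc1nc(N2CCCC2)c2ncn(/C=C3/CC3(CO)CO)c2n1` gives > 24000 nM as a limit
- compound 3 `Nc1nc(NC2CCCC2)c2ncn(/C=C3/CC3(CO)CO)c2n1` gives > 20000 nM as a limit

Compound 3 stands at the limit of > 20000 nM in this assay, at which 2 of the 3 values shown sit, and so offers no exact starting number. In compound 4 `CSc1nc(N)nc2c1ncn2/C=C1/CC1(CO)CO` methylsulfanyl takes the place of cyclopentylamino on an aromatic carbon next to the ring nitrogen (methylsulfanyl in place of cyclopentylamino on an aromatic carbon) and the rest of the structure stays the same.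

Three measured steps exchange groups on an aromatic carbon: there is a step that the two limits leave unreadable from compound 1 to compound 2 and a step that the two limits leave unreadable from compound 1 to compound 3 and also a step that the two limits leave unreadable from compound 2 to compound 3 so none of them has a usable size. With compound 3 reaching > 20000 nM as a limit, no step beyond the usual scatter is expected in this assay and no direction can be named. The expected change is a step that the limit leaves unreadable from compound 3 to compound 4 as an estimate only. For compound 4 the estimate is 25000 nM with an expected range from 10000 nM to 60000 nM and the outcome may well be only a limit.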

Compound 4, half-maximal cytotoxic concentration: > 20000 nM
Compound 4: a limit, no number; the forecaster's own chance of this, stated with the estimate: 80%; the middle value lies beyond the limit too.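

Compound 4 also gives only a limit and not a number, so no new step can be read between it and compound 1, compound 2 or compound 3: the limit of > 20000 nM in this assay, at which 3 of the 4 values shown sit.

In this assay the compounds shown leave open whether the four groups on the aromatic carbon differ at all.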